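The source may report more compounds than this note shows. Statements on the series, on what has been measured and on what is new or still open speak of the compounds shown alone.

Of the compounds shown here, three with a shared core have been measured in a functional assay on NCI-H460 cells (Homo sapiens) for antiproliferative activity, with a stated time of 72 h; on this read-out lower numbers stand for stronger inhibition and higher numbers for weaker inhibition. Compound 1 `C=CC[C@H]1C[C@]2(CCc3ccc(OC)c(OC)c3)OCOC2=CC1=O` gives 3200 nM. Compound 2 `C=CC[C@H]1C[C@]2([C@H](C)Cc3ccc(OC)cc3)OCOC2=CC1=O` gives 120 nM. Compound 3 `C=CC[C@H]1C[C@]2([C@@H](C)Cc3ccccc3)OCOC2=CC1=O` gives 9700 nM. On these numbers compound 3 stands highest, which on this read-out means the weakest antiproliferative effect: its distance to compound 1 is beyond the scatter, and its distance to compound 2 is far beyond it. Compound 2, which carries a methoxy group on the aromatic ring where compound 3 carries only hydrogen, and which also differs from compound 3 at the stereocentre bearing the methyl group, is the most potent of the three.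

Compound 4 `C=CC[C@H]1C[C@]2([C@@H](C)Cc3ccc(OC(F)(F)F)cc3)OCOC2=CC1=O` is not yet measured. It differs from compound 3 in one place: trifluoromethoxy in place of hydrogen on an aromatic carbon. Among the measured compounds shown here, since compound 2 and compound 3 differ in more than one place, no single step between measured compounds tells what a substituent at this ring position alone does. Still, the two values show that the ring-substituted compound 2 sits well below the unsubstituted compound 3. A step from compound 3 to compound 4 of a 6.5-fold lower number from compound 3 to compound 4 (0.81 log units; beyond the scatter) toward stronger inhibition is therefore expected, though with wide uncertainty. Compound 4 is estimated at 1500 nM, with a range from 300 nM to 8000 nM in this assay.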

Compound 4, half-maximal inhibitory concentration: 3800 nM
The estimate for compound 4 lay 2.5-fold (0.40 log units) below the measured number; low and high end bracket the measured number.
By their numbers in this assay, from the lowest: compound 2; then compounds 1 and 4 (each within the scatter of the next); then compound 3.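

In this assay, among the compounds shown here, trifluoromethoxy in place of hydrogen on an aromatic carbon gives a 2.6-fold lower number from compound 3 to compound 4 (0.41 log units; beyond the scatter), the only step here in which a single change can be read on its own. This shows that the ring position para to a large group can carry a substituent of 5 heavy atoms without any loss of antiproliferative activity, and that this change brings a modest gain. The compounds shown come with no measurement that would explain this gain, so the step stands as an observation without a known cause.

Going by these compounds, whether the gain is particular to trifluoromethoxy remains open, as a single substituent cannot show how this position responds to other groups, such as a fluorine atom, an amine or a carboxylic acid on the same aromatic carbon. Also open, on these data alone, is how much of the activity of compound 2, at 120 nM, comes from its methoxy group and how much from the stereocentre bearing the methyl group; it differs from compound 3 at both.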